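The compounds below may be only part of what the source reports. "The series", "measured", "known", "first", "only" and "open" are said of these compounds alone.

Compound 1, `COC[C@@H](C(C)C)C(c1ccc(O)c(OC)c1)c1ccc(O)c(OC)c1`, in a functional assay on HeLa cells (Homo sapiens) for cytotoxicity, read by WST assay, with a stated time of 48 h (a higher number here means a weaker inhibitor, a lower number a stronger inhibitor), gives 69000 nM.
Compound 2, `COC[C@H](C(C)C)C(c1ccc(O)c(OC)c1)c1ccc(O)c(OC)c1`, gives 76000 nM.
Compound 3, `COc1ccc(C(c2ccc(OC)c(OC)c2)[C@H](C)[C@@H](C)CO)cc1OC`, gives 67000 nM.

The three numbers sit close together. Compound 2 is separated from compound 1 by a 1.1-fold higher number from compound 1 to compound 2 (0.04 log units; within the scatter), and compound 3 lies within the scatter of compound 2 as well, so none of the three can be told apart on these figures.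

The step to be followed leads from compound 2 to compound 4, `COc1cc(C(c2ccc(O)c(OC)c2)[C@H](CC(C)C)C(C)C)ccc1O`. The change is isopropyl in place of methoxy on a saturated chain carbon, three bonds along the chain from two aromatic carbons.

Among the measured compounds shown here, only one measured step is available, that from compound 1 to compound 2, and it is a change of configuration alone, due to the fact that compounds 1 and 2 differ only in the configuration as drawn; it left the number essentially where it was. For the measured compounds named here, it says nothing about exchanging one group for another on the saturated chain carbon, so no measured step bears directly on the change to compound 4. Three compounds with differing substitution at the chain and at the aromatic oxygens all give numbers within the scatter of each other, which gives no ground to expect a move in either direction.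

Compound 4 is therefore expected to give about 70000 nM, between 30000 nM and 160000 nM. That would mean an expected step of a 1.1-fold lower number from compound 2 to compound 4 (0.04 log units; within the scatter), within the scatter.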

Compound 4, half-maximal inhibitory concentration: 8200 nM
Compound 4: middle estimate off by 8.5-fold (0.93 log units), on the high side; measured number outside the range, below it.
By their numbers in this assay, from the lowest: compound 4; then compounds 3, 1 and 2 (each within the scatter of the next).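

In this assay the earlier compounds had all stayed within the scatter of one another, whereas isopropyl in place of methoxy on a saturated chain carbon, three bonds along the chain from two aromatic carbons, gives a 9.3-fold lower number from compound 2 to compound 4 (0.97 log units; beyond the scatter), so this position responds to the group it carries in a way the change of configuration alone had not shown. Read one bond further out, 1-isopropyl-3-methylbutyl in place of 1-(methoxymethyl)-2-methylpropyl on a saturated chain carbon bound to two aromatic carbons gives an 8.4-fold lower number from compound 1 to compound 4 (0.93 log units; beyond the scatter), a step of like size, so the drop appears from either drawn configuration of the methoxymethyl compounds. Nothing available here explains why the number falls with this exchange.

As far as these compounds go, whether the number would go on falling with a longer chain or a cyclohexyl at this place, or would return with an amine or a carboxylic acid there, remains open. Also open, from the compounds shown here alone, is whether the opposite configuration of compound 4 would match it, as the configuration made no readable difference between the methoxymethyl compounds.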